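The source may report more compounds than this note shows. Statements on the series, on what has been measured and on what is new or still open speak of the compounds shown alone.

Of the compounds shown here, three that share a core have been read in a functional assay on MIA PaCa-2 cells (Homo sapiens) for inhibition, read by MTT assay, with a stated time of 48 h, tested at 10 uM; a lower number here means less inhibition of growth, a higher number more inhibition of growth at the concentration tested. Compound 1 `Cc1cc(=O)c2c(O)cc(OCc3ccc(Br)cc3)c([C@H]3CCN(C)C[C@H]3O)c2o1` gives 13%, compound 2 `Cc1cc(=O)c2c(O)cc(OC/C=C/c3ccccc3)c([C@H]3CCN(C)C[C@H]3O)c2o1` gives 11%, and compound 3 `Cc1oc2c([C@H]3CCN(C)C[C@H]3O)c(O)cc(O)c2c(=O)c1C(O)c1ccc(Cl)cc1` gives 15%. These numbers all lie within the usual scatter of one another, so compound 3 stands level with the other two and cannot be ranked against them.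

Compound 4 `Cc1oc2c([C@H]3CCN(C)C[C@H]3O)c(O)cc(O)c2c(=O)c1C(O)c1c(Cl)cccc1Cl` differs from compound 3 in one place: 2,6-dichlorophenyl in place of 4-chlorophenyl on a saturated chain carbon bound to an aromatic carbon and an oxygen on a saturated carbon. Here, 2,6-dichlorophenyl takes the place of 4-chlorophenyl on a saturated chain carbon bound to an aromatic carbon and an oxygen on a saturated carbon. Among the compounds with values here, only one measured step exists, a number 2 percentage points lower from compound 1 to compound 2 (within the scatter). It exchanges a different group at a different place, so it offers only a loose guide to this change. Within the data shown here, it does show a swap of groups that stays small, and no measurement yet tests the new group itself. No step beyond the scatter is therefore expected, and the estimated step is a number 1 percentage points higher from compound 3 to compound 4 (within the scatter). The expected value for compound 4 is 16%, with an estimated range of 5% to 32%.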

Compound 4, percent growth inhibition at one concentration: 0%
Beside the measured number, compound 4's estimate is 16 percentage points above it; the whole stated range lies above it.
By their numbers in this assay, from the lowest: compound 4; then compounds 2, 1 and 3 (each within the scatter of the next).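

In this assay, placing 2,6-dichlorophenyl instead of 4-chlorophenyl on the saturated chain carbon bound to an aromatic carbon and an oxygen on a saturated carbon gives a number 15 percentage points lower from compound 3 to compound 4 (beyond the scatter) and is the only step shown that lies beyond the scatter. The group at this position can therefore change the read-out, even when both groups are chlorine-bearing phenyl rings. Nothing available explains why the number falls.

The compounds shown leave open how a plain phenyl ring, a pyridine ring or a small alkyl chain at this position would read. They also leave open whether any group here could lift growth inhibition well past the level of compound 3, which gives 15% in this assay.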